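Swapping methyl for fluoro on the pendant phenyl ring

The compounds below may be only part of what the source reports. "The series", "measured", "known", "first", "only" and "open" are said of these compounds alone.

Compound 3 `Cc1ccc(-c2nn3cc(-c4cccc(N)c4)nc3s2)cc1` is measured in a functional assay on L1210 cells (Mus musculus) for inhibition, read by cell counting, with a stated time of 2 days (on this read-out higher numbers stand for weaker inhibition and lower numbers for stronger inhibition), and gives 4800 nM. Among the three measured compounds it stands second highest: compound 1 `C=C(Br)C(=O)Nc1cccc(-c2cn3nc(-c4ccc(F)cc4)sc3n2)c1` gives 250 nM, and compound 2 `CCOc1ccc(-c2nn3cc(-c4cccc(N)c4)nc3s2)cc1` gives 155000 nM. Within the data shown here, the one comparable step known so far is a 32-fold lower number from compound 2 to compound 3 (1.51 log units; beyond the scatter), showing that a change at this position of the ring can shift the number a great deal. Compound 4 `Nc1cccc(-c2cn3nc(-c4ccc(F)cc4)sc3n2)c1` differs from compound 3 by fluoro in place of methyl on an aromatic carbon, on an aromatic carbon of a six-membered aromatic ring of carbon only. Among the measured compounds shown here, no measured pair shows methyl against fluoro, so the direction is uncertain; compound 1 carries the same fluoro but also a different group on the other ring, and its value cannot be read as a guide. The expected step is therefore small, a 1.0-fold higher number from compound 3 to compound 4 (0.02 log units; within the scatter), within the usual scatter. Compound 4 is estimated at 5000 nM, with a likely range from 1500 nM to 20000 nM.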

Compound 4, half-maximal inhibitory concentration: >= 250000 nM
Compound 4: no number, only a limit; the forecaster's own chance of this, stated with the estimate: 5%; middle value at least 50-fold (1.69 log units) from the limit.
By their numbers in this assay, from the lowest: compound 1; then compound 3; then compound 2. At a limit, above all of these: compound 4.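

In this assay compound 4 reads >= 250000 nM as a limit of the assay, not a number. Going from 4-methylphenyl to 4-fluorophenyl gives an at least 52-fold higher number from compound 3 to compound 4 (1.71 log units; beyond the scatter) and so shows that exchanging one heavy atom at this place on the ring can matter a great deal, even though the earlier ethoxy-to-methyl step gave no sign of how fluoro would behave. Fluoro in place of ethoxy gives an at least 1.6-fold higher number from compound 2 to compound 4 (0.20 log units; that floor lies within the scatter) and leaves the order of those two unsettled, while hydrogen in place of (1-bromoethenyl)carbonyl on the nitrogen gives an at least 1000-fold higher number from compound 1 to compound 4 (3.00 log units; beyond the scatter) and shows how much the low number of the fluoro series rests on that group.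

Where chloro, methoxy or plain hydrogen would fall at this place on the ring stays open. Also open, on these data alone, is whether a simpler acetyl on the nitrogen would keep any of that large difference, or whether the (1-bromoethenyl)carbonyl group would do the same alongside 4-methylphenyl.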